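Notes on the step from compound 3 to compound 4

The compounds below may be only part of what the source reports. "The series", "measured", "known", "first", "only" and "open" are said of these compounds alone.

In an ADME assay on microsomes from liver (Mus musculus) for metabolic stability, read by LC-MS, with NADPH named in the record, with a stated time of 60 min, tested at 1 uM, in the absence of a further agent (on this read-out lower numbers stand for a less stable compound and higher numbers for a more stable compound), compound 3 (`COc1ccc(-c2c(C)nc3c(N4CC=CC4)cc(C)nn23)cc1OC`) gives > 95% as a limit of the assay, not a number. Compound 1 (`COc1ccc(-c2c(C)nc3c(N4CC[C@@H](NS(=O)(=O)C5CC5)C4)cc(C)nn23)cc1OC`) gives > 95% and this too is a limit. Compound 2 (`COc1ccc(-c2c(C)nc3c(N4CC[C@@H](NS(=O)(=O)c5ccc(C)cc5)C4)cc(C)nn23)cc1OC`) gives > 95% and this too is a limit. Among the compounds with values here, all values so far stand at the limit of > 95% in this assay, at which 3 of the 3 values shown sit, so no order among the three can be read.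

Compound 4 (`COc1ccc(-c2c(C)nc3c(N4CC[C@@H](O)C4)cc(C)nn23)cc1OC`) brings 3-hydroxypyrrolidin-1-yl onto the shared core: a group of 6 heavy atoms (4 carbon, 1 nitrogen, 1 oxygen; one five-membered non-aromatic ring with 1 hetero atom) in place of a group of 5 heavy atoms (4 carbon, 1 nitrogen; one five-membered non-aromatic ring with 1 hetero atom), on an aromatic carbon is the whole of the change.

Within the data shown here, the one measured step, a step that the two limits leave unreadable from compound 1 to compound 2 gives no size to carry over. Among the measured compounds shown here, it concerns a different group, and no measured step covers this exchange directly. Compound 2 also holds a substituted five-membered non-aromatic ring with 1 hetero atom in that place and still gives > 95% as a limit. On that basis, no step beyond the usual scatter is expected in this assay although a modest fall cannot be excluded with limits alone. The estimate gives a number at least 3 percentage points lower from compound 3 to compound 4 (that floor lies within the scatter) as the expected step. For compound 4 the estimated value is 92% within an expected range of 75% to 100% in this assay.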

Compound 4, percent of the compound remaining: > 95%
Compound 4 gave a limit, no number (the forecaster's own chance of this, stated with the estimate: 55%); middle value at least 3 percentage points away from the limit.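

In this assay compound 4 gives > 95%, a limit of the assay and not a number. No step can be read between compound 4 and compounds 1, 2 or 3, because all four share one limit: the limit of > 95% in this assay, at which 4 of the 4 values shown sit.

The compounds shown leave open how the four differ in stability, and whether any change on the shared core would bring a value below that limit.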